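Diaryl ether in place of biaryl on the shared core

A few compounds are considered here, and "the series" means these few. Any claim that something is new, unique, unknown or untested is made for them only; others in the source may bear on it.

The three measured compounds share one core. In an assay on isolated protein for agonist activity at Bile acid receptor (Homo sapiens), read by AlphaScreen, with a stated time of 30 min (on this read-out lower numbers stand for smaller maximal responses and higher numbers for larger maximal responses), compound 1 `COc1ccc(C2SC(C)C(=O)Nc3c2c(C)nn3-c2ccccc2C)c(OC)c1` gives 63%, compound 3 `Cc1nn(-c2ccccc2C(F)(F)F)c2c1C(c1ccc(Oc3ccccc3)cc1)SC(C)C(=O)N2` gives 50%, and compound 2 `COc1cccc(-c2ccc([C@H]3S[C@@H](C)C(=O)Nc4c3c(C)nn4-c3ccccc3C)cc2)c1` gives 41%. Compound 2 thus has the lowest of the three numbers; its gap to compound 3 lies within the scatter, while its gap to compound 1 lies beyond it. Compound 4 `COc1cccc(Oc2ccc([C@H]3S[C@@H](C)C(=O)Nc4c3c(C)nn4-c3ccccc3C)cc2)c1` differs from compound 2 in one place: 3-methoxyphenoxy in place of 3-methoxyphenyl on an aromatic carbon. Within the data shown here, no step between two measured compounds isolates this change, so only compound 3, which also carries an aryl ether and gives 50%, offers a hint. The step of a number 7 percentage points higher from compound 2 to compound 4 (within the scatter) is expected to be small, upward, and not beyond the scatter. Compound 4 is therefore estimated at 48%, within 32% to 64%.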

Compound 4, largest response reached (reported as efficacy), in percent of the reference or control that the assay uses: 120%
The estimate for compound 4 lay 72 percentage points below the measured number; the measured number lies above the stated range.
By their numbers in this assay, from the lowest: compounds 2 and 3 (each within the scatter of the next); then compound 1; then compound 4.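

In this assay, 3-methoxyphenoxy in place of 3-methoxyphenyl on an aromatic carbon para to a large group gives a number 79 percentage points higher from compound 2 to compound 4 (beyond the scatter). Among these compounds, this first single-place comparison shows that the maximal response at this position depends strongly on how the outer ring is attached, a dependence that the earlier compounds could not isolate. Nothing available explains the size of this step. The compounds shown leave open whether a thioether or methylene link would act like the ether oxygen. They also leave open whether the step would persist with an amine or a carboxylic acid in place of the methoxy group.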